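Series notes: 4-methylphenyl to 4-chlorophenyl

This account rests on a few compounds, and the source may have more. Where it says the series, first, only, none or still open, it means among the compounds named here.

Measured so far in a functional assay on K562 cells (Homo sapiens) for cytotoxicity, read by MTT assay, with a stated time of 72 h (a higher number here means a weaker inhibitor, a lower number a stronger inhibitor), for this series:
compound 1 `Cc1ccc(S(=O)(=O)n2cc(COC3=C/C(=N\c4ccccc4)c4ccccc4C3=O)nn2)cc1` gives 12200 nM
compound 2 `Cc1ccc(/N=C2\C=C(OCc3cn(S(=O)(=O)c4ccc(C)cc4)nn3)C(=O)c3ccccc32)cc1` gives 6220 nM

Within the data shown here, compound 2 stands level with compound 1, its only measured neighbour. Compound 3 `Cc1ccc(S(=O)(=O)n2cc(COC3=C/C(=N\c4ccc(Cl)cc4)c4ccccc4C3=O)nn2)cc1` follows from compound 2 by chloro in place of methyl on an aromatic carbon, para to a large group. Among the measured compounds shown here, the only measured step bearing on this, methyl in place of hydrogen on an aromatic carbon, is a 2.0-fold lower number from compound 1 to compound 2 (0.29 log units; within the scatter), so no step beyond the scatter is expected in this assay here. The estimated move is a 1.0-fold lower number from compound 2 to compound 3 (0.02 log units; within the scatter) for now. Compound 3 is expected at 6000 nM, with an estimated range from 2200 nM to 16000 nM in this series.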

Compound 3, half-maximal inhibitory concentration: 9800 nM
Beside the measured number, compound 3's estimate is 1.6-fold (0.21 log units) below it, and the stated range covers the measured number.
By their numbers in this assay, from the lowest: compounds 2, 3 and 1 (each within the scatter of the next).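

In this assay the change from 4-methylphenyl to 4-chlorophenyl gives a 1.6-fold higher number from compound 2 to compound 3 (0.20 log units; within the scatter) and chloro in place of hydrogen on the same ring gives a 1.2-fold lower number from compound 1 to compound 3 (0.10 log units; within the scatter) in this series. Hydrogen, methyl and chloro have now all been read at this position, para to a large group, and no step among them leaves the scatter. No evidence available here bears on this result.

The compounds shown leave open whether an amine or a carboxylic acid at this position would move the number beyond the scatter. They also leave open whether the same holds for a methoxy group.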